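This account rests on a few compounds, and the source may have more. Where it says the series, first, only, none or still open, it means among the compounds named here.

Measured in a functional assay on HEK293 cells for antagonist activity at transient receptor potential cation channel subfamily V member 1 (Rattus norvegicus), read by calcium flux; on this read-out higher numbers stand for weaker inhibition and lower numbers for stronger inhibition:
compound 1, `Cc1cccc(C)c1Nc1nc2c(Nc3ccc(C(F)(F)F)cc3)ncnc2s1`, 6 nM
compound 2, `FC(F)(F)c1cccc(Nc2ncnc3sc(Nc4c(Cl)cccc4Cl)nc23)c1`, 192 nM
compound 3, `Cc1ccc(Nc2ncnc3sc(Nc4c(Cl)cccc4Cl)nc23)cc1`, 32 nM

Compound 3 holds the middle of the three numbers in this assay. Its number sits beyond the scatter on both sides: compound 1 lies lower, compound 2 lies higher. All three share one core; they differ in the aryl group attached to it and in its substitution, and no two of them differ in one place only, so no single step can be read off among the measured compounds.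

Compound 4, `O=S(=O)(c1ccc(Nc2ncnc3sc(Nc4c(Cl)cccc4Cl)nc23)cc1)N1CCCC1`, is not yet measured. Against compound 3 the change is (pyrrolidin-1-yl)sulfonyl in place of methyl on an aromatic carbon, para to a large group. Nothing in the data shows the size of such a change. The expectation is a step toward a higher number, of a size somewhat beyond the scatter, and the estimated step is a 2.2-fold higher number from compound 3 to compound 4 (0.34 log units; beyond the scatter). For compound 4 the estimate in this assay is 70 nM, with a range from 15 nM to 350 nM.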

Compound 4, half-maximal inhibitory concentration: 0.5 nM
Compound 4: middle estimate off by 140-fold (2.15 log units), on the high side, and the stated range ends above it.
By their numbers in this assay, from the lowest: compound 4; then compound 1; then compound 3; then compound 2.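

In this assay the position that carries methyl in compound 3 accepts a far larger substituent, and (pyrrolidin-1-yl)sulfonyl on this aromatic carbon, para to a large group, gives a 64-fold lower number from compound 3 to compound 4 (1.81 log units; beyond the scatter) and a large gain in inhibition. For the compounds shown here, this is the first step that can be read at a single place, and it shows that a group with a five-membered non-aromatic ring and hydrogen-bond acceptors is not merely tolerated here but goes with stronger inhibition. No measurement shown here accounts for the size of this step.

The sulfonyl and the pyrrolidine ring enter together, so an open-chain dimethylaminosulfonyl, a primary sulfonamide or a piperidinylsulfonyl group would be needed to separate their shares. From the compounds shown here alone, whether the same change carries over to the aryl group of compound 1 also stays open.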